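Aryl amides on a shared boron core: toward compound 4

The source may hold more compounds than are shown below. What is called first, only, known or untested is meant among the compounds shown, and "the series" means these compounds.

Measured so far in a functional assay on MDA-MB-231 cells (Homo sapiens) for antiproliferative activity, read by MTT assay, with a stated time of 72 h; on this read-out lower numbers stand for stronger inhibition and higher numbers for weaker inhibition:
compound 1 `CC(C)(C)c1ccc(NC(=O)CCc2cccc3c2B(O)OC3)cc1` — 33000 nM
compound 2 `O=C(CCc1cccc2c1B(O)OC2)Nc1cccc2ccccc12` — 150 nM
compound 3 `O=C(CCc1cccc2c1B(O)OC2)Nc1cccc(-c2ccc(F)cc2)c1` — 250 nM

Compound 3 holds the second highest of the three numbers. Its nearest neighbour is compound 2, whose value sits within the scatter of that of compound 3, so the two cannot be ordered. Among the compounds with values here, the furthest is compound 1, whose number lies far beyond the scatter on the weaker side; compound 1 and compound 3 share the core and differ only in the aryl amide portion, and no single step between them is computed here, so only the two values themselves are compared.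

Compound 4 `CC(=O)c1cccc(-c2cccc(NC(=O)CCc3cccc4c3B(O)OC4)c2)c1` is not yet measured. It differs from compound 3 in one place: 3-acetylphenyl in place of 4-fluorophenyl on an aromatic carbon. The new group is larger by the counted atoms and brings one hydrogen-bond acceptor where the departing group had none, on an aromatic carbon meta to a large group.

Within the data shown here, with no measured step on this kind of change, the expectation rests on the closeness of compound 2 and compound 3. For compound 4 the step of a 1.2-fold higher number from compound 3 to compound 4 (0.08 log units; within the scatter) is expected to stay within the scatter, in no firm direction. Compound 4 is therefore estimated at 300 nM, with a range from 100 nM to 1000 nM in this assay.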

Compound 4, half-maximal inhibitory concentration: 52 nM
Compound 4: middle estimate off by 5.8-fold (0.76 log units), on the high side, and the stated range ends above it.
By their numbers in this assay, from the lowest: compound 4; then compounds 2 and 3 (each within the scatter of the next); then compound 1.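

Working notes on the series: in this assay, 3-acetylphenyl in place of 4-fluorophenyl, on an aromatic carbon meta to a large group, gives a 4.8-fold lower number from compound 3 to compound 4 (0.68 log units; beyond the scatter), the first single-place step available here. Within the data shown here, this position is therefore sensitive to the identity of the aryl group it carries, a point that the earlier compounds, which offered no such step, could not establish. The change alters several things at once, since the entering group has 9 heavy atoms and 1 hydrogen-bond acceptor against 7 and 0 for the leaving group, and it also moves the substituent on the ring; no available data explain the lower number.

As far as these compounds go, it remains open whether the carbonyl of the acetyl group carries the step or whether a plain phenyl, a nitrile, a carboxylic acid or an amine on the same ring would give a similar number. From the compounds shown here alone, it is also open whether the step would persist with a longer chain between the shared core and the amide.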